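Dropping the fluoropyridinyl group from compound 3

The source may report more compounds than this note shows. Statements on the series, on what has been measured and on what is new or still open speak of the compounds shown alone.

Compound 3 `C[C@@H](Oc1cc2oc(=O)n(CCC(=O)O)c2cc1Cl)c1ccc(F)cn1` gives 2.51 nM in an assay for inhibition of kynurenine 3-monooxygenase (Homo sapiens), read by mass spectrometry, with a stated time of 1 h (a lower number here means a stronger inhibitor, a higher number a weaker inhibitor), the lowest of the three numbers. Compound 2 `O=C(O)CCn1c(=O)oc2cc(OCc3ccccn3)c(Cl)cc21` gives 3.16 nM, within the scatter of compound 3, while compound 1 `O=C(O)CCn1c(=O)oc2cc(OCc3ccccc3)c(Cl)cc21` gives 25.1 nM, beyond it. Compound 4 `CCOc1cc2oc(=O)n(CCC(=O)O)c2cc1Cl` differs from compound 3 by hydrogen in place of 5-fluoropyridin-2-yl on a saturated chain carbon bound to an oxygen on an aromatic ring and a saturated chain carbon. For the measured compounds named here, no measured step removes this group; the only step, a 7.9-fold lower number from compound 1 to compound 2 (0.90 log units; beyond the scatter), swaps one ring for another rather than taking it away, so it bears on compound 4 only loosely. Because that ring swap alone moved the number by a 7.9-fold lower number from compound 1 to compound 2 (0.90 log units; beyond the scatter), losing the whole ring is expected to weaken inhibition more. For compound 4 the expected step is a 120-fold higher number from compound 3 to compound 4 (2.08 log units; beyond the scatter), an estimate of 300 nM in this assay, between 40 nM and 2500 nM.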

Compound 4, half-maximal inhibitory concentration: 5.01 nM
Compound 4: the middle estimate sits 60-fold (1.78 log units) above what was measured, outside the stated range (below it).
By their numbers in this assay, from the lowest: compounds 3, 2 and 4 (each within the scatter of the next); then compound 1.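

Hydrogen in place of 5-fluoropyridin-2-yl gives a 2.0-fold higher number from compound 3 to compound 4 (0.30 log units; within the scatter) and methyl in place of pyridin-2-yl gives a 1.6-fold higher number from compound 2 to compound 4 (0.20 log units; within the scatter) so a low number in these compounds does not depend on an aromatic ring at this position. Methyl in place of phenyl gives a 5.0-fold lower number from compound 1 to compound 4 (0.70 log units; beyond the scatter) so among the rings shown only phenyl goes with a number clearly above that of the small group. Nothing shown here explains this. Open, going by these compounds, is whether a longer chain or an amine on this carbon would keep the number as low.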